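The source may report more compounds than this note shows. Statements on the series, on what has been measured and on what is new or still open speak of the compounds shown alone.

Measured so far in a functional assay on DU-145 cells (Homo sapiens) for inhibition; a higher number here means a weaker inhibitor, a lower number a stronger inhibitor:
- compound 1 `Oc1ccc(-c2cc(-c3cccc(F)c3)cc(-c3ccccc3O)n2)cc1`: > 50000 nM (a limit)
- compound 2 `Oc1ccc(-c2cc(-c3cccc(F)c3)cc(-c3cccc(O)c3)n2)cc1`: 2700 nM

Compound 1 has no number, only a limit: it stands at the limit of > 50000 nM in this assay, at which 1 of the 2 values shown sits. Compound 3 `Oc1ccc(-c2cc(-c3cccc(C(F)(F)F)c3)cc(-c3ccccc3O)n2)cc1` keeps the 2-hydroxyphenyl of compound 1 and changes in one place: trifluoromethyl in place of fluoro on an aromatic carbon. Going by the values given here, the only measured step is an at least 18-fold lower number from compound 1 to compound 2 (1.26 log units; beyond the scatter). It is large, but it swaps the hydroxyphenyl and leaves the fluoro untouched, so it gives no size for this change. In this assay the expected step is therefore none beyond the scatter, in no set direction: a number no higher from compound 1 to compound 3 (the limit leaves the size open). For compound 3 the estimated value is 50000 nM, with an expected range of 15000 nM to 100000 nM.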

Compound 3, half-maximal inhibitory concentration: > 50000 nM
Compound 3 gave a limit, no number (the forecaster's own chance of this, stated with the estimate: 65%); the middle value lies on the limit itself.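

Compound 1 and compound 3 both give only limits in this assay, so no step between them can be read: the limit of > 50000 nM in this assay, at which 2 of the 3 values shown sit.

The compounds shown leave open what trifluoromethyl in place of fluoro does to inhibition, including alongside the 3-hydroxyphenyl of compound 2.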